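Removing a Fluoro Group: Compound 2 to Compound 3

This account rests on a few compounds, and the source may have more. Where it says the series, first, only, none or still open, it means among the compounds named here.

Compound 1 `O=C(O)c1cc(F)c(F)cc1O` and compound 2 `CC(=O)Oc1c(C(=O)O)cc(F)c(F)c1F` were both tested in a toxicity assay on the whole organism (strain CD-1) for cytotoxicity, with Mus musculus as the target, with a stated time of 14 days, at a dose of 150 mg/kg by the intraperitoneal route; a higher number here means a weaker effect of the compound at the dose given, a lower number a stronger effect. In this assay compound 1 gives 66% and compound 2 gives 70%, the higher of the two numbers, though the gap to compound 1 lies within the usual scatter. Compound 3 `CC(=O)Oc1cc(F)c(F)cc1C(=O)O` has not yet been measured. It differs from compound 2 by hydrogen in place of fluoro on an aromatic carbon. For the measured compounds named here, with no step between measured compounds to draw on, the step of a number 2 percentage points lower from compound 2 to compound 3 (within the scatter) is expected to be small, with no change beyond the scatter in this assay. Compound 3 is therefore estimated at 68%, between 50% and 85%.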

Compound 3, a percentage reported as activity, at one dose (the size of the read-out at that dose, not a potency): 100%
Estimate against measurement, compound 3: 32 percentage points below, and the stated range ends below it.
By their numbers in this assay, from the lowest: compounds 1 and 2 (each within the scatter of the next); then compound 3.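

In this assay, for the compounds shown here, the earlier compounds offered no step to read, and this result gives the first: hydrogen in place of fluoro on this aromatic carbon is a number 30 percentage points higher from compound 2 to compound 3 (beyond the scatter), a weaker effect at the dose given. Acetyl in place of hydrogen on the oxygen is a number 34 percentage points higher from compound 1 to compound 3 (beyond the scatter), so that change also shifts the read-out beyond the scatter. Nothing available explains either step.

The compounds shown leave open how chlorine or an amine on this aromatic carbon would read. They also leave open how a longer acyl chain, such as propionyl, would read on the oxygen.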